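From cyclobutylcarbonyl to ethylcarbamoyl: an untested step

This account rests on a few compounds, and the source may have more. Where it says the series, first, only, none or still open, it means among the compounds named here.

Compound 1 `O=C(Nc1ccc2nc(NC(=O)C3CCCCC3)sc2c1)c1cccc(F)c1`: 0.64 ug/mL
Compound 2 `O=C(Nc1ccc2nc(NC(=O)C3CCC3)sc2c1)c1c(Cl)cccc1Cl`: 0.013 ug/mL

Both numbers come from a functional assay on WI-38 VA13 cells (Homo sapiens) for cytotoxicity; on this read-out higher numbers stand for an effect only at larger amounts of compound and lower numbers for an effect already at smaller amounts. Of the two, compound 2 shows the lower number, and its gap to compound 1 lies beyond the scatter. Compound 3 `CCNC(=O)Nc1nc2ccc(NC(=O)c3c(Cl)cccc3Cl)cc2s1` has not yet been measured. It differs from compound 2 in one place: ethylamino in place of cyclobutyl on a carbonyl carbon. Within the data shown here, no measured pair shows this change, so its effect is unknown; a modest shift toward a higher number is expected, though it may stay within the scatter. Compound 3 is estimated to give 0.03 ug/mL in this assay, within a range from 0.005 ug/mL to 0.2 ug/mL. This expectation corresponds to a step of a 2.3-fold higher number from compound 2 to compound 3 (0.36 log units; beyond the scatter).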

Compound 3, half-maximal effective concentration: 0.032 ug/mL
For compound 3 the middle estimate is 1.1-fold (0.03 log units) below the measured one; the measured number falls inside the stated range.
By their numbers in this assay, from the lowest: compound 2; then compound 3; then compound 1.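

In this assay, among these compounds, replacing cyclobutyl with ethylamino on this carbonyl carbon gives a 2.5-fold higher number from compound 2 to compound 3 (0.39 log units; beyond the scatter) and is the first single change measured at this place. The ring is therefore not required for an effect at small amounts, although the change still moves the number beyond the scatter. Nothing available explains this step.

The two compounds cannot separate losing the ring from adding the nitrogen, which cyclobutylamino could help to resolve. As far as these compounds go, how a shorter methylamino or longer propylamino group would behave also remains open.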